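Benzyl-substituted pyrazole series: moving to 2-methylphenyl

The source may hold more compounds than are shown below. What is called first, only, known or untested is meant among the compounds shown, and "the series" means these compounds.

Within the data shown here, compound 1 `CCCn1c(=O)c2nc(-c3cnn(Cc4cc(C(F)(F)F)ccc4Cl)c3)[nH]c2n(CCC)c1=O` is the one member of this set with a number in hand: in an assay on CHO cells for displacement of a labelled ligand from adenosine receptor A1 (Homo sapiens) (on this read-out lower numbers stand for stronger inhibition and higher numbers for weaker inhibition), compound 1 gives 1200 nM. Among the measured compounds shown here, compound 2 `CCCn1c(=O)c2nc(-c3cnn(Cc4ccc(OC)c(C(F)(F)F)c4)c3)[nH]c2n(CCC)c1=O` and compound 3 `CCCn1c(=O)c2nc(-c3cnn(Cc4cc(C(F)(F)F)cc(Cl)c4F)c3)[nH]c2n(CCC)c1=O` carry the same core with other substituted benzyl groups, but for compound 2 the result in this assay is "not determined" (no result reported) and for compound 3 it is likewise "not determined" (no result reported), so no step between measured compounds can be drawn and nothing is known about how changes on the benzyl ring move the read-out.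

Compound 4 `CCCn1c(=O)c2nc(-c3cnn(Cc4ccccc4C)c3)[nH]c2n(CCC)c1=O` differs from compound 1 in one place: 2-methylphenyl in place of 2-chloro-5-(trifluoromethyl)phenyl on a saturated chain carbon bound to an aromatic nitrogen. For the measured compounds named here, with no measured step to lean on, the expectation for compound 4 rests on compound 1 alone, and the step of a 1.3-fold higher number from compound 1 to compound 4 (0.10 log units; within the scatter) is estimated to lie within the usual scatter, in no firm direction. Compound 4 is therefore expected to give about 1500 nM in this assay, with a wide range from 400 nM to 6000 nM reflecting the absence of any comparator.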

Compound 4, inhibition constant: 22 nM
Beside the measured number, compound 4's estimate is 68-fold (1.83 log units) above it, outside the stated range (below it).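

In this assay, among these compounds, a 55-fold lower number from compound 1 to compound 4 (1.74 log units; beyond the scatter) is the first readable step, and it shows that the read-out is highly sensitive to the aryl group on a saturated chain carbon bound to an aromatic nitrogen. The change removes the chloro and trifluoromethyl substituents and introduces a methyl group in one move, so this single step cannot show which part of the exchange accounts for the difference. No measurement is available here that bears on the origin of this step.

Steps involving compound 2 and compound 3 cannot be read, so the methoxy and fluoro variants of the benzyl ring add nothing yet. Also open, from the compounds shown here alone, is how an unsubstituted phenyl, or an amine or a carboxylic acid on the ring, would compare with the 2-methylphenyl group of compound 4.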